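Chloro to dimethylamino: a step from level ground

The compounds below may be only part of what the source reports. "The series", "measured", "known", "first", "only" and "open" are said of these compounds alone.

Measured in a functional assay on HepG2 cells (Homo sapiens) for cytotoxicity, read by MTT assay, with a stated time of 48 h; on this read-out lower numbers stand for stronger inhibition and higher numbers for weaker inhibition:

Compound 1 `O=C1/C(=C\c2ccccc2)S/C(=N/c2ccccc2)N1Cc1ccncc1`: 25200 nM
Compound 2 `Cc1ccc(/C=C2/S/C(=N/c3ccccc3)N(Cc3ccncc3)C2=O)cc1`: 19700 nM
Compound 3 `O=C1/C(=C\c2ccc(Cl)cc2)S/C(=N/c2ccccc2)N1Cc1ccncc1`: 28800 nM

Compound 3, at 28800 nM, lies within the scatter of both other compounds, so the three cannot be put in order. The next compound to consider is compound 4 `CN(C)c1ccc(/C=C2/S/C(=N/c3ccccc3)N(Cc3ccncc3)C2=O)cc1`, which has dimethylamino in place of chloro on an aromatic carbon, para to a large group (dimethylamino in place of chloro on an aromatic carbon). Cut one bond further out, the change reads 4-chlorophenyl to 4-(dimethylamino)phenyl.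

Three measured swaps at that place bear on this change. Methyl in place of hydrogen gave a 1.3-fold lower number from compound 1 to compound 2 (0.11 log units; within the scatter), chloro in place of hydrogen gave a 1.1-fold higher number from compound 1 to compound 3 (0.06 log units; within the scatter), and chloro in place of methyl gave a 1.5-fold higher number from compound 2 to compound 3 (0.16 log units; within the scatter). None of them goes beyond the scatter. Dimethylamino itself has no measured precedent in this small set, so the guidance is limited and the range is kept wide. Still, no step beyond the scatter is expected in this assay. The expected change is a 1.4-fold lower number from compound 3 to compound 4 (0.16 log units; within the scatter). For compound 4 the estimated value is 20000 nM, with an expected range from 8000 nM to 45000 nM.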

Compound 4, half-maximal inhibitory concentration: 52600 nM
Estimate against measurement, compound 4: 2.6-fold (0.42 log units) below; the measured number lies above the stated range.
By their numbers in this assay, from the lowest: compounds 2, 1, 3 and 4 (each within the scatter of the next, the first and the last beyond it).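

Dimethylamino is the first group at this position to move the number beyond the scatter: this assay records a 2.1-fold higher number from compound 1 to compound 4 (0.32 log units; beyond the scatter) when it replaces hydrogen and a 2.7-fold higher number from compound 2 to compound 4 (0.43 log units; beyond the scatter) when it replaces methyl, both modest steps toward weaker inhibition. Against chloro, the same swap gives a 1.8-fold higher number from compound 3 to compound 4 (0.26 log units; within the scatter) and cannot be read as a real change, so compound 3 and compound 4 cannot be put in order. This position is therefore not wholly indifferent to what sits on it, although the effect shows only against hydrogen and methyl.

Going by these compounds, whether an amino group, a methoxy group or a carboxylic acid at the same place would behave like dimethylamino remains open. No measurement shown here explains the shift.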